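A few compounds are considered here, and "the series" means these few. Any claim that something is new, unique, unknown or untested is made for them only; others in the source may bear on it.

Within the data shown here, two measured points define the series so far in a functional assay for inhibition, with Homo sapiens as the target; a lower number here means tighter binding, a higher number weaker binding. Compound 1 (`O=C(O)CC/C=C\CC1COC(c2ccc3ccccc3c2)OC1c1cccnc1`) gives 1780 nM. Compound 2 (`CSc1ccc(OC(C)(C)C2OCC(C/C=C\CCC(=O)O)C(c3cccnc3)O2)c([N+](=O)[O-])c1`) gives 4.47 nM, the lower of the two numbers, and the gap between them lies beyond the scatter. Among the measured compounds shown here, these two compounds differ in more than one place, so no single-change step is available for calibration.

Compound 3 (`CSc1ccccc1OC(C)(C)C1OCC(C/C=C\CCC(=O)O)C(c2cccnc2)O1`) is not yet measured and differs from compound 2 in one place: a group of 8 heavy atoms (7 carbon, 1 sulfur; one six-membered aromatic ring of carbon only) in place of a group of 11 heavy atoms (7 carbon, 1 nitrogen, 2 oxygen, 1 sulfur; one six-membered aromatic ring of carbon only), on an oxygen on a saturated carbon. The entering group is 2-(methylsulfanyl)phenyl, and the change sits on an oxygen on a saturated carbon. For the measured compounds named here, the data hold no measured precedent for this replacement, so the expectation is a judgement with a wide range. Going by the values given here, a moderate rise in the number is expected in this assay, because compound 2 stands at 4.47 nM and the only other measured compound stands far higher. The expected change is a 4.5-fold higher number from compound 2 to compound 3 (0.65 log units; beyond the scatter). Compound 3 is estimated at 20 nM, with an expected range of 5 nM to 80 nM.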

Compound 3, dissociation constant: 89.1 nM
Beside the measured number, compound 3's estimate is 4.5-fold (0.65 log units) below it; the whole stated range lies below it.
By their numbers in this assay, from the lowest: compound 2; then compound 3; then compound 1.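

In this assay, among these compounds, putting 2-(methylsulfanyl)phenyl in place of the group of 11 heavy atoms, on an oxygen on a saturated carbon, gives a 20-fold higher number from compound 2 to compound 3 (1.30 log units; beyond the scatter), the first single-change step. This place therefore has a large bearing on the number, and the 2-(methylsulfanyl)phenyl group alone does not keep the value of compound 2: the group that leaves carries a nitrogen and two oxygens more, with 3 hydrogen-bond acceptors against 1, and in this pair it goes with the tighter binding. No available measurement gives a reason for the size of this step.

Going by these compounds, it remains open whether the rise follows from the loss of the nitrogen and both oxygens as one unit, or whether another group on the same aromatic ring, such as a nitrile or an amine, would restore the number. One pair also leaves open whether a step of this size would recur with a longer chain in place of the one carrying the carboxylic acid.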